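Swapping Bromine for Methyl in a Histamine H2 Agonist Series

The source may report more compounds than this note shows. Statements on the series, on what has been measured and on what is new or still open speak of the compounds shown alone.

Compound 1 `CCCCCNC(=O)/N=C(\N)NCCCc1sc(N)nc1C`: 0.78
Compound 2 `Cc1nc(N)sc1CCCN/C(N)=N/C(=O)NC(C)c1ccc(Br)cc1`: 0.87
Compound 3 `Cc1nc(N)sc1CCCN/C(N)=N/C(=O)NC(c1ccccc1)C(C)C`: 1.04

All three compounds were tested in a functional assay on Right cardiac atrium for agonist activity at histamine H2 receptor (Cavia porcellus), with a stated time of 30 min, in the presence of a further agent that is not named here; on this read-out lower numbers stand for smaller maximal responses and higher numbers for larger maximal responses. Compound 2 gives the second highest of the three numbers: its value lies within the usual scatter of compound 1, whereas compound 3 stands beyond the scatter above it. Compound 4 `Cc1ccc(C(C)NC(=O)/N=C(\N)NCCCc2sc(N)nc2C)cc1` is not yet measured. It differs from compound 2 in one place: methyl in place of bromo on an aromatic carbon. Among the compounds with values here, no two measured compounds differ in only one place, so there is no earlier step of this kind to draw on. All three measured values cluster near the reference response, and no step beyond the scatter is expected in this assay. Compound 4 is estimated at 0.88, expected between 0.72 and 1.04. The expected step is a number 0.010 higher from compound 2 to compound 4 (within the scatter).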

Compound 4, intrinsic activity: the largest response reached, as a fraction of the reference agonist's: 0.85
Compound 4: middle estimate off by 0.030, on the high side, and the stated range covers the measured number.
By their numbers in this assay, from the lowest: compounds 1, 4 and 2 (each within the scatter of the next); then compound 3.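

This pair is the first shown that differs in one place only, giving a direct reading of the group on the aromatic ring. In this assay the step is a number 0.020 lower from compound 2 to compound 4 (within the scatter) when 4-bromophenyl becomes 4-methylphenyl. At this position, bromo and methyl therefore cannot be told apart by maximal response, and nothing available offers a reason for this. Still open, as far as these compounds go, is whether a larger or different group in the same place, such as an amine, a carboxylic acid or a longer chain, would also stay within the scatter of compound 2.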